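The source may hold more compounds than are shown below. What is called first, only, known or untested is meant among the compounds shown, and "the series" means these compounds.

Working notes on the series. The shared core carries an acyl urea on one side and an acyl hydrazone on the other. Compound 1 `CN(C(=O)NC(=O)c1cccc([N+](=O)[O-])c1)c1nc(C(F)(F)F)c(C(=O)N/N=C/c2ccccc2C(F)(F)F)s1` gives 3.97 ug/mL in a functional assay on BCG823 cells (Homo sapiens) for inhibition, read by MTT assay, with a stated time of 72 h; on this read-out higher numbers stand for weaker inhibition and lower numbers for stronger inhibition. Compound 2 `CN(C(=O)NC(=O)c1ccc(F)c(F)c1)c1nc(C(F)(F)F)c(C(=O)N/N=C/c2cccc(C(F)(F)F)c2)s1` gives 4.46 ug/mL in this assay, and compound 3 `CN(C(=O)NC(=O)c1ccc(F)c(F)c1)c1nc(C(F)(F)F)c(C(=O)N/N=C/c2cc(C(F)(F)F)cc(C(F)(F)F)c2)s1` gives 3.51 ug/mL in this assay. Among the measured compounds shown here, the only single-point step measured so far, a 1.3-fold lower number from compound 2 to compound 3 (0.10 log units; within the scatter), sits on the hydrazone side. Compound 3 has the lowest number of the three, but its gaps to compound 1 and to compound 2 both lie within the scatter, so no order among them can be read.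

Compound 4 `CN(C(=O)NC(=O)c1ccc(Cl)cc1Cl)c1nc(C(F)(F)F)c(C(=O)N/N=C/c2cc(C(F)(F)F)cc(C(F)(F)F)c2)s1` differs from compound 3 by 2,4-dichlorophenyl in place of 3,4-difluorophenyl on a carbonyl carbon. For the measured compounds named here, no measured step touches this position: compound 1 and compound 2 carry different acyl groups there, but they also differ on the hydrazone side, so their two values say nothing separable about the acyl change alone. With nothing bearing on it, the expectation for compound 4 is no step beyond the scatter, a 1.0-fold lower number from compound 3 to compound 4 (0.00 log units; within the scatter), giving an estimated 3.5 ug/mL in this assay, with a range from 1.7 ug/mL to 7.5 ug/mL.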

Compound 4, half-maximal inhibitory concentration: > 100 ug/mL
Compound 4: only a limit was reported; the forecaster's own chance of this, stated with the estimate: 5%; middle value at least 28-fold (1.45 log units) away from the limit.
By their numbers in this assay, from the lowest: compounds 3, 1 and 2 (each within the scatter of the next). At a limit, above all of these: compound 4.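

The acyl position on the urea side is not neutral: 2,4-dichlorophenyl in place of 3,4-difluorophenyl on a carbonyl carbon, with the hydrazone side unchanged, gives an at least 28-fold higher number from compound 3 to compound 4 (1.45 log units; beyond the scatter). Among the compounds shown here, this is the first measured step at this position and the first beyond the scatter, whereas the step on the hydrazone side, a 1.3-fold lower number from compound 2 to compound 3 (0.10 log units; within the scatter), stays within it. The value of compound 4 is a limit and not a number, so the step has no upper end: the limit of > 100 ug/mL in this assay, at which 1 of the 4 values shown sits.

On these data alone, whether the change follows the chlorine atoms or their placement remains open; 3,4-dichlorophenyl or 2,4-difluorophenyl at this place would separate the two. Also open, as far as these compounds go, is how this assay reads when the aryl ring on this carbonyl carries an amine or a carboxylic acid.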